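The source may hold more compounds than are shown below. What is called first, only, known or untested is meant among the compounds shown, and "the series" means these compounds.

Measured in a functional assay on HepG2 cells (Homo sapiens) for antiproliferative activity, read by MTT assay, with a stated time of 48 h; a lower number here means a stronger inhibitor, a higher number a weaker inhibitor:
Compound 1 `CC(=O)N1N=C(c2ccc3ccccc3c2)OC1c1ccccc1Br`: 3.98 ug/mL
Compound 2 `CC(=O)N1N=C(c2ccc3ccccc3c2)OC1c1cccc(Br)c1`: 1.68 ug/mL

Of the two compounds measured, compound 2 has the lower number and therefore the stronger inhibition. Among the measured compounds shown here, the only measured step is a 2.4-fold lower number from compound 1 to compound 2 (0.37 log units; beyond the scatter), a modest change that lies beyond the scatter. It replaces 2-bromophenyl with 3-bromophenyl on a saturated ring carbon.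

Compound 3 `CC(=O)N1N=C(c2ccc3ccccc3c2)OC1c1ccc(Br)cc1` has not yet been measured. It keeps the shared core and differs from compound 2 in one place: 4-bromophenyl in place of 3-bromophenyl on a saturated ring carbon.

For the measured compounds named here, only the step to compound 2 bears on this change, since it also moves the bromine around the phenyl ring. One step does not establish a trend, and the data do not show whether the number would fall further or turn back. In this assay, a change no larger than that single modest step is therefore expected, in no firm direction, and it may stay within the scatter.

The expected change is a 1.3-fold higher number from compound 2 to compound 3 (0.12 log units; within the scatter).

For compound 3 the estimated value is 2.2 ug/mL, with an expected range from 0.9 ug/mL to 5 ug/mL.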

Compound 3, half-maximal inhibitory concentration: 2.08 ug/mL
Beside the measured number, compound 3's estimate is 1.1-fold (0.02 log units) above it; low and high end bracket the measured number.
By their numbers in this assay, from the lowest: compounds 2, 3 and 1 (each within the scatter of the next, the first and the last beyond it).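

In this assay, exchanging 3-bromophenyl for 4-bromophenyl on the saturated ring carbon gives a 1.2-fold higher number from compound 2 to compound 3 (0.09 log units; within the scatter), so these two placements of the bromine cannot be told apart, and the drop seen on the first move is not extended. Among the compounds shown here, the new compound also qualifies that first result: a 1.9-fold lower number from compound 1 to compound 3 (0.28 log units; within the scatter) likewise stays inside the scatter, which leaves a 2.4-fold lower number from compound 1 to compound 2 (0.37 log units; beyond the scatter) as the only step among the three bromophenyl groups that clears it, and that step is modest. No measurement available here offers a reason for these numbers.

The three compounds leave open whether anything other than bromine on this phenyl ring would move the number well beyond the scatter, for instance a fluorine, a methoxy group, a dimethylamino group or a carboxylic acid, or whether a phenyl ring with no bromine at all would do the same. They also leave open how the acetyl group on the neighbouring ring nitrogen contributes, and whether a longer chain such as propanoyl would change the number in its place.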